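The source may hold more compounds than are shown below. What is called first, only, known or untested is meant among the compounds shown, and "the series" means these compounds.

Measured compounds:
compound 1 `CC(C)(C)Oc1cc2oc(-c3ccccc3)cc(=O)c2c(O)c1O` — 40.5 ug/mL
compound 2 `O=c1cc(-c2ccc(O)c(O)c2)oc2cc(OCc3ccc(F)cc3)cc(O)c12` — 16.2 ug/mL

Two compounds were tested in an ADME assay on C8166 cells (Homo sapiens) for inhibition, read by MTT assay, with a stated time of 72 h; on this read-out lower numbers stand for higher toxicity in this test and higher numbers for lower toxicity in this test. Compound 1 gives 40.5 ug/mL, the highest of the two numbers. Compound 2 gives 16.2 ug/mL, a number that stands beyond the scatter from compound 1 and marks compound 2 as the more toxic of the pair.

Compound 3 `CC(C)(C)Oc1cc(O)c2c(=O)cc(-c3ccccc3)oc2c1` has not yet been measured in this assay. It differs from compound 1 in one place: hydrogen in place of hydroxy on an aromatic carbon. For the measured compounds named here, no pair of measured compounds shows what the loss of a hydroxy group does here, so the expectation rests on compound 1 alone. The step from compound 1 to compound 3 in this assay is expected to be a 1.2-fold lower number from compound 1 to compound 3 (0.06 log units; within the scatter), that is, no change beyond the scatter in either direction. Compound 3 is therefore estimated at 35 ug/mL, with a range from 15 ug/mL to 90 ug/mL.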

Compound 3, half-maximal cytotoxic concentration: 61.2 ug/mL
Compound 3: middle estimate off by 1.7-fold (0.24 log units), on the low side; the measured number falls inside the stated range.
By their numbers in this assay, from the lowest: compound 2; then compounds 1 and 3 (each within the scatter of the next).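

Hydrogen in place of hydroxy on this aromatic carbon, ortho to a hydroxy group and to a tert-butoxy group, gives in this assay a 1.5-fold higher number from compound 1 to compound 3 (0.18 log units; within the scatter) and so leaves the number unchanged within the usual scatter. For the compounds shown here, this is the first direct reading of this position: on the core of compound 1, the hydroxy group there can be lost without a measurable shift in this test. Nothing measured here offers a reason for this outcome.

The compounds shown leave open whether other groups on this carbon, such as a methoxy group, an amine or a fluorine atom, would also leave the number in place. They also leave open whether the same change would read the same way if the tert-butoxy group gave way to a longer chain or a benzyl ether.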